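The compounds below may be only part of what the source reports. "The series", "measured", "known", "first", "only" and "open" are said of these compounds alone.

Measured so far in a functional assay on A549 cells (Homo sapiens) for antiproliferative activity, read by MTT assay, with a stated time of 48 h; on this read-out higher numbers stand for weaker inhibition and lower numbers for stronger inhibition:
compound 1 `CC(=O)Nc1ccc(-n2nncc2CN2C(=O)C3(C(C#N)=C(N)Oc4c(N)cc5nc6ccccc6nc5c43)c3ccccc32)cc1` — > 50000 nM (a limit of the assay)
compound 2 `Cc1ccc(C)c(-n2nncc2CN2C(=O)C3(C(C#N)=C(N)Oc4c(N)cc5nc6ccccc6nc5c43)c3ccccc32)c1` — > 50000 nM (a limit of the assay)

Compound 1 gives only a limit in this assay, not a number. Compound 2 likewise gives only a limit in this assay. The step that the two limits leave unreadable from compound 1 to compound 2 is therefore not readable in size; both values sit at the same limit (the limit of > 50000 nM in this assay, at which 2 of the 2 values shown sit). Compound 2 thus stands at the limit and nothing more can be said of its place among the numbers shown.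

Compound 3 `COc1ccc(OC)c(-n2nncc2CN2C(=O)C3(C(C#N)=C(N)Oc4c(N)cc5nc6ccccc6nc5c43)c3ccccc32)c1` is not yet measured. It differs from compound 2 by 2,5-dimethoxyphenyl in place of 2,5-dimethylphenyl on an aromatic nitrogen. For the measured compounds named here, the one measured step on this aromatic nitrogen, the step from compound 1 to compound 2, is unreadable, so no size can be read from it for the change to compound 3. The expectation is that compound 3 again falls at or near the limit; the estimated step that the limit leaves unreadable from compound 2 to compound 3 is therefore none beyond the scatter. The estimate for compound 3 in this assay is 60000 nM, with a range from 20000 nM to 200000 nM.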

Compound 3, half-maximal inhibitory concentration: 28100 nM
Beside the measured number, compound 3's estimate is 2.1-fold (0.33 log units) above it; the range from low to high includes it.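

In this assay compound 3 is the only one of the three with a number rather than a limit, so the group on this aromatic nitrogen now has one readable value, while the other two values are limits: (the limit of > 50000 nM in this assay, at which 2 of the 3 values shown sit). With 2,5-dimethoxyphenyl in place of 2,5-dimethylphenyl the result is an at least 1.7-fold lower number from compound 2 to compound 3 (0.25 log units; that floor lies within the scatter) and with it in place of 4-acetamidophenyl the result is an at least 1.7-fold lower number from compound 1 to compound 3 (0.25 log units; that floor lies within the scatter) so both steps are floors only. On these data alone, neither floor establishes a change beyond the scatter, and the true size of each step remains unknown.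

The compounds shown do not separate the contribution of the two methoxy groups from that of either one alone. As far as these compounds go, how an unsubstituted phenyl, a 4-methoxyphenyl or a 2,5-dichlorophenyl on this nitrogen would read also remains open.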